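From a Ring-Bearing Alkyne to an Open Alkene Chain

The source may report more compounds than this note shows. Statements on the series, on what has been measured and on what is new or still open speak of the compounds shown alone.

Of the compounds shown here, three sharing one core have been tested in an assay on isolated protein for binding affinity to vitamin D3 receptor (Homo sapiens), read by fluorescence polarization, tested at 1 uM; on this read-out lower numbers stand for less inhibition and higher numbers for more inhibition at the one concentration tested (going by the name of the read-out). Compound 1 `CCN(CC)CCNC(=O)C1CC=C(C(CC)(CC)c2ccc(C#CC(C)(C)O)c(C)c2)N1CC` gives 60.2%, compound 2 `CCN(CC)CCNC(=O)C1CC=C(C(CC)(CC)c2ccc(C#CC(C)(O)CC)c(C)c2)N1CC` gives 63.4%, and compound 3 `CCN(CC)CCNC(=O)C1CC=C(C(CC)(CC)c2ccc(C#CC(O)C3CCCC3)c(C)c2)N1CC` gives 47.9%. Compound 3 thus stands lowest of the three, with both other numbers beyond the scatter above it: a number 12.3 percentage points lower from compound 1 to compound 3 (beyond the scatter) and a number 15.5 percentage points lower from compound 2 to compound 3 (beyond the scatter). The remaining step, a number 3.2 percentage points higher from compound 1 to compound 2 (within the scatter), is within the scatter.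

Compound 4 `CCN(CC)CCNC(=O)C1CC=C(C(CC)(CC)c2ccc(/C=C/C(C)(O)CC)c(C)c2)N1CC` is compound 3 with one alteration: a group of 7 heavy atoms (6 carbon, 1 oxygen; no ring) in place of a group of 9 heavy atoms (8 carbon, 1 oxygen; one five-membered non-aromatic ring of carbon only), on an aromatic carbon. The entering group ends in the same 1-hydroxy-1-methylpropyl unit found in compound 2, but it is attached through a double bond instead of a triple bond. The measured step bearing most directly on this change is a number 15.5 percentage points lower from compound 2 to compound 3 (beyond the scatter), which runs in the opposite direction to the present head-group exchange. Going by the values given here, no measured pair informs the replacement of a triple bond by a double bond, so that part of the change carries uncertainty. Because of a number 15.5 percentage points lower from compound 2 to compound 3 (beyond the scatter), compound 4 is expected to recover much of that loss through a step of a number 10.1 percentage points higher from compound 3 to compound 4 (beyond the scatter) in this assay. The estimate for compound 4 is 58%, with a range from 45% to 70%.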

Compound 4, a percentage reported as inhibition, at one concentration (the size of the read-out at that concentration, not a potency): 68.9%
Compound 4: middle estimate off by 10.9 percentage points, on the low side; the range from low to high includes it.
By their numbers in this assay, from the lowest: compound 3; then compounds 1, 2 and 4 (each within the scatter of the next).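

With the 1-hydroxy-1-methylpropyl end kept on the aromatic carbon, a double bond in place of a triple bond gives a number 5.5 percentage points higher from compound 2 to compound 4 (within the scatter) in this assay, so this exchange of bonds moves the number no further than the usual spread. Going by these compounds alone, the open-chain alkene also shows a number 8.7 percentage points higher from compound 1 to compound 4 (within the scatter) against the smaller 1-hydroxy-1-methylethyl alkyne, while a number 21 percentage points higher from compound 3 to compound 4 (beyond the scatter) marks a clear gap from the cyclopentyl-bearing alkyne, the one compound of the four set apart from the rest. No measured evidence is available to explain these numbers. From the compounds shown here alone, it remains open whether the double bond would give a similar number with the cyclopentyl(hydroxy)methyl end. Also open, going by these compounds, is what a saturated two-carbon link, or an amine or carboxylic acid in place of the hydroxyl, would do at this position.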